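The source may report more compounds than this note shows. Statements on the series, on what has been measured and on what is new or still open speak of the compounds shown alone.

Of the compounds shown here, three built on one shared core have been measured in an assay for binding affinity to histamine H2 receptor (Homo sapiens); a higher number here means a weaker inhibitor, a lower number a stronger inhibitor. Compound 1 `CC(C)(C)OC[C@@H](N)C(=O)N1CCN(CCCOc2ccc(C(=O)C3CC3)cc2)CC1` gives 45700 nM, compound 2 `CC(C)(C)[C@@H](N)C(=O)N1CCN(CCCOc2ccc(C(=O)C3CC3)cc2)CC1` gives 19100 nM, and compound 3 `CNCC(=O)N1CCN(CCCOc2ccc(C(=O)C3CC3)cc2)CC1` gives 79400 nM. Compound 3 therefore carries the highest of the three numbers; its nearest neighbour is compound 1, where a 1.7-fold higher number from compound 1 to compound 3 (0.24 log units; within the scatter), a gap within the usual scatter, so the two cannot be told apart, while compound 2 lies furthest, with a 4.2-fold higher number from compound 2 to compound 3 (0.62 log units; beyond the scatter). For the measured compounds named here, the only other measured step is a 2.4-fold lower number from compound 1 to compound 2 (0.38 log units; beyond the scatter), and it also concerns the group on the carbonyl carbon.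

Compound 4 `NCCC(=O)N1CCN(CCCOc2ccc(C(=O)C3CC3)cc2)CC1` has not been measured. It holds the same atoms as compound 3, joined differently: aminomethyl in place of methylamino on a saturated chain carbon bound to a carbonyl carbon. Going by the values given here, no measured step alters this place in this way; the two steps that lead to compound 3 each exchange the whole group on the carbonyl carbon rather than rearranging it, so they bear only loosely on this change. With the atoms unchanged, the expectation in this assay is for no step beyond the scatter. Compound 4 is thus estimated to give 80000 nM, within 35000 nM to 180000 nM, which means an expected step of a 1.0-fold higher number from compound 3 to compound 4 (0.00 log units; within the scatter).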

Compound 4, inhibition constant: 100000 nM
Estimate against measurement, compound 4: 1.3-fold (0.10 log units) below; the measured number falls inside the stated range.
By their numbers in this assay, from the lowest: compound 2; then compounds 1, 3 and 4 (each within the scatter of the next, the first and the last beyond it).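

Rearranging the same atoms, with aminomethyl in place of methylamino on a saturated chain carbon bound to a carbonyl carbon, gives a 1.3-fold higher number from compound 3 to compound 4 (0.10 log units; within the scatter) in this assay and so leaves compound 3 and compound 4 indistinguishable, a test of this place that the earlier whole-group exchanges could not give. Set against the larger groups, the 2-aminoethyl group of compound 4 gives a 5.2-fold higher number from compound 2 to compound 4 (0.72 log units; beyond the scatter) and also a 2.2-fold higher number from compound 1 to compound 4 (0.34 log units; beyond the scatter) in this assay, and both steps lie beyond the scatter, whereas the step from compound 1 to compound 3 stayed within it, so that boundary is narrow and a small gap between two such steps should not be overread. Nothing measured on these compounds offers a reason for any of these differences.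

The compounds shown leave open whether a longer chain such as 3-aminopropyl would keep the number in this range, or whether moving the nitrogen further along has any effect at all. They also leave open what a dimethylamino group, or a hydroxyl group in place of the amine, would do at this place.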